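Cytotoxicity limits in the series: phenyl to hydroxy

The compounds below may be only part of what the source reports. "The series", "measured", "known", "first", "only" and "open" are said of these compounds alone.

Compound 1 `C=C[C@](C)(CCCC(C)C)CCc1ccc(O)cc1`: > 36600 nM (a limit)
Compound 2 `C=C[C@@](C)(/C=C/c1ccc(O)c(/C=C/C(=O)c2ccccc2)c1)CCC=C(C)C`: > 20000 nM (a limit)

In an ADME assay on BJ cells (Homo sapiens) for cytotoxicity, with a stated time of 72 h (a lower number here means that less compound is needed, a higher number that more compound is needed for the effect), compound 2 stands at > 20000 nM, which is a limit and not a number. Compound 1 also gives only a limit, > 36600 nM. No true reading exists yet for either compound, so no order can be drawn between them.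

Compound 3 `C=C[C@@](C)(/C=C/c1ccc(O)c(/C=C/C(=O)O)c1)CCC=C(C)C` carries hydroxy in place of phenyl on a carbonyl carbon, which, cut one bond further out, reads benzoyl to carboxy: hydroxy in place of phenyl on a carbonyl carbon. Going by the values given here, no measured pair isolates this change. The expectation rests on compound 2 and its limit of > 20000 nM. No step beyond the scatter is expected in this assay, and no direction is favoured. The estimated change is a step that the limit leaves unreadable from compound 2 to compound 3. The assay is expected to report a limit again rather than a number. Compound 3 is estimated at 28000 nM, with an expected range of 12000 nM to 60000 nM.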

Compound 3, half-maximal effective concentration: > 36600 nM
Compound 3: no number, only a limit (the forecaster's own chance of this, stated with the estimate: 85%); at least 1.3-fold (0.11 log units) between middle value and limit.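

In this assay compound 3 gives > 36600 nM, a limit and not a number. Compound 2 gives > 20000 nM, also a limit. Going by these compounds alone, no step can therefore be read between compound 2 and compound 3. The compounds shown leave open how far benzoyl to carboxy moves the half-maximal effective concentration in this assay.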